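The compounds below may be only part of what the source reports. "The series", "measured", "known", "first", "only" and "open" are said of these compounds alone.

Compound 1 `COc1cc2c(Nc3ccc(C#N)cc3)ncnc2cc1OCCCN(C)C`, compound 2 `CCN(CC)CCCOc1cc2ncnc(Nc3ccc(C#N)cc3)c2cc1OC` and compound 3 `COc1cc2c(Nc3ccc(C#N)cc3)ncnc2cc1OCCCN1CCC(C)CC1` share one core and differ only in the amine carried on a saturated chain carbon, three bonds along the chain from an oxygen on an aromatic ring. In a functional assay on SH-SY5Y cells (Homo sapiens) for antiproliferative activity, read by MTT assay, with a stated time of 72 h (a lower number here means a stronger inhibitor, a higher number a weaker inhibitor), compound 1 gives 34900 nM. Compound 2 reaches only a limit of the assay, > 100000 nM, and no number. Compound 3 gives 7900 nM in this assay. The swap of dimethylamino for diethylamino brings an at least 2.8-fold higher number from compound 1 to compound 2 (0.45 log units; beyond the scatter); the ring amine brings a 4.4-fold lower number from compound 1 to compound 3 (0.65 log units; beyond the scatter) and an at least 12-fold lower number from compound 2 to compound 3 (1.10 log units; beyond the scatter). Compound 3 therefore holds the lowest of the two numbers shown, with compound 1 nearest to it.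

Compound 4 `CCOC(=O)C1CCN(CCCOc2cc3ncnc(Nc4ccc(C#N)cc4)c3cc2OC)CC1` keeps that ring amine and alters its far side: ethoxycarbonyl in place of methyl on a saturated ring carbon. Going by the values given here, none of the measured steps touches a substituent on that ring; each exchanges the whole amine, and each shifted the number by a modest or large amount. Among the compounds with values here, the gap between compound 1 and compound 3 is the closest guide, showing that the ring terminus itself counts, but no measured step tells what a group on its saturated ring carbon does. The expectation is a step of a 1.5-fold higher number from compound 3 to compound 4 (0.18 log units; within the scatter), within or near the scatter. For compound 4 in this assay the estimate is 12000 nM, with a range from 4000 nM to 40000 nM.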

Compound 4, half-maximal inhibitory concentration: 47200 nM
For compound 4 the middle estimate is 3.9-fold (0.59 log units) below the measured one; the whole stated range lies below it.
By their numbers in this assay, from the lowest: compound 3; then compounds 1 and 4 (each within the scatter of the next). At a limit, above all of these: compound 2.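

Going by these compounds alone, the far side of the ring amine proves to count: in this assay, ethoxycarbonyl in place of methyl on a saturated ring carbon, three ring bonds from the ring nitrogen, brings a 6.0-fold higher number from compound 3 to compound 4 (0.78 log units; beyond the scatter), the first measured change at this position and one beyond the scatter. The advantage that 4-methylpiperidin-1-yl held over dimethylamino, a 4.4-fold lower number from compound 1 to compound 3 (0.65 log units; beyond the scatter), is not kept by 4-(ethoxycarbonyl)piperidin-1-yl, which gives a 1.4-fold higher number from compound 1 to compound 4 (0.13 log units; within the scatter), so that compound 1 and compound 4 stand level. Against diethylamino the ester-bearing ring amine still reads as an at least 2.1-fold lower number from compound 2 to compound 4 (0.32 log units; beyond the scatter), but one end of that step is a limit of the assay and not a number: the limit of > 100000 nM in this assay, at which 1 of the 4 values shown sits.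

The compounds shown do not separate the added heavy atoms of ethoxycarbonyl from its hydrogen-bond acceptors, and a propyl group, a carboxylic acid or an amide on the same ring carbon would bear on that question. Going by these compounds, whether the same exchange would carry the same weight on a longer chain between the oxygen and the ring nitrogen also stays open.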